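A few compounds are considered here, and "the series" means these few. Any claim that something is new, unique, unknown or untested is made for them only; others in the source may bear on it.

Compound 1 `COc1ccc2nccc(C3CN(C4CCN(Cc5cc6ccccc6n5C)CC4)C(=O)O3)c2c1`: 3160 nM
Compound 2 `COc1ccc(CN2CCC(N3CC(c4ccnc5ccc(OC)cc45)OC3=O)CC2)cc1`: 1260 nM

Both numbers come from an in vitro functional assay on RBL cells for antagonist activity at C-C chemokine receptor type 8 (Homo sapiens), read by FLIPR and calcium flux; on this read-out lower numbers stand for stronger inhibition and higher numbers for weaker inhibition. Going by the values given here, on these two numbers, compound 2 stands at the lower one: the one measured step, a 2.5-fold lower number from compound 1 to compound 2 (0.40 log units; beyond the scatter), separates it from compound 1. Compound 3 `COc1ccc2nccc(C3CN(C4CCN(Cc5ccc(Cl)c(Cl)c5)CC4)C(=O)O3)c2c1` is not yet measured; it differs from compound 2 in one place: 3,4-dichlorophenyl in place of 4-methoxyphenyl on a saturated chain carbon bound to an amine nitrogen in a ring. Among the compounds with values here, the only measured step, from compound 1 to compound 2, changed the same position, and its size shows that this position can move the number by a modest amount. Within the data shown here, no measured step swaps a methoxyphenyl for a dichlorophenyl, so no direction is directly supported; the step from compound 1 to compound 2 says only that the number may shift. For compound 3 a modest move in either direction, or none beyond the scatter, is possible, and the estimate for compound 3 is 800 nM, with a range of 250 nM to 3000 nM, which is expected to mean a 1.6-fold lower number from compound 2 to compound 3 (0.20 log units; within the scatter).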

Compound 3, half-maximal inhibitory concentration: 126 nM
Compound 3: the middle estimate sits 6.3-fold (0.80 log units) above what was measured; the whole stated range lies above it.
By their numbers in this assay, from the lowest: compound 3; then compound 2; then compound 1.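

Changing 4-methoxyphenyl to 3,4-dichlorophenyl on a saturated chain carbon bound to an amine nitrogen in a ring gives, in this assay, a 10-fold lower number from compound 2 to compound 3 (1.00 log units; beyond the scatter) and shows that this position can move the number further than the earlier 2.5-fold lower number from compound 1 to compound 2 (0.40 log units; beyond the scatter) did. The 3,4-dichlorophenyl group also outdoes 1-methyl-1H-indol-2-yl at the same place, with a 25-fold lower number from compound 1 to compound 3 (1.40 log units; beyond the scatter) on an otherwise unchanged structure, so the three groups now fall in a clear order. No measurement at hand explains why the number falls.

Going by these compounds, how 4-chlorophenyl or 3-chlorophenyl, each with a single chlorine, would compare remains open, as does a phenyl ring carrying a carboxylic acid. On these data alone, all three compounds share the rest of their structure, so the effect of changes elsewhere in the core is also open.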